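The source may report more compounds than this note shows. Statements on the series, on what has been measured and on what is new or still open speak of the compounds shown alone.

Measured compounds:
compound 1 `COc1ccc(-c2cc(-c3cc(OC)c(OC)c(OC)c3)nc(-c3ccccn3)n2)cc1` — 50000 nM
compound 2 `COc1ccc(C2=NN(C(C)=O)C(c3cc(OC)c(OC)c(OC)c3)C2)cc1` — 200000 nM

In an ADME assay on THP-1 cells (Homo sapiens) for cytotoxicity, read by MTT assay (on this read-out higher numbers stand for lower toxicity in this test and lower numbers for higher toxicity in this test), compound 1 gives 50000 nM, the lowest of the two numbers; compound 2 gives 200000 nM, a higher figure beyond the scatter. The compound not yet measured, compound 3 `COc1ccc(-c2cc(-c3cc(OC)c(OC)c(OC)c3)nc(-c3cccnc3)n2)cc1`, differs from compound 1 in one place: pyridin-3-yl in place of pyridin-2-yl on an aromatic carbon. Among the measured compounds shown here, no measured pair shows this change, so its effect is unknown here. Compound 3 is expected to stay near compound 1, with a step of no change at the digits printed from compound 1 to compound 3 (within the scatter) that is not beyond the scatter. For compound 3 the estimate in this assay is 50000 nM, within 20000 nM to 150000 nM.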

Compound 3, half-maximal cytotoxic concentration: 200000 nM
The estimate for compound 3 lay 4.0-fold (0.60 log units) below the measured number, outside the stated range (above it).
By their numbers in this assay, from the lowest: compound 1; then compounds 2 and 3 (each within the scatter of the next).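

In this assay, pyridin-3-yl in place of pyridin-2-yl on the aromatic carbon between two ring nitrogen atoms gives a 4.0-fold higher number from compound 1 to compound 3 (0.60 log units; beyond the scatter), so the read-out at this position depends on how the pyridine ring is joined, though the two groups have the same atoms. Among the compounds shown here, this is the first pair to show a change at this place, and it moves towards lower toxicity in this test. Nothing given here bears on why the step occurs. The compounds shown leave open how pyridin-4-yl, phenyl or an amine on this carbon would read. They also leave open whether the same change gives a similar step on another core.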